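The source may hold more compounds than are shown below. What is called first, only, known or untested is meant among the compounds shown, and "the series" means these compounds.

Measured in an ADME assay on BJ cells (Homo sapiens) for cytotoxicity, with a stated time of 72 h; a higher number here means that more compound is needed for the effect, a lower number that less compound is needed:
- Compound 1 `COc1cc2ncnc(-n3nc(-c4ccccn4)nc3N)c2cc1OCc1ccccc1`: > 27000 nM
- Compound 2 `COc1cc2ncnc(-n3nc(-c4ccccn4)nc3N)c2cc1OCCCN(C)C`: > 25000 nM
- Compound 3 `COc1cc2ncnc(-n3nc(-c4ccccn4)nc3N)c2cc1OCCCN1CC(C)OC(C)C1`: > 25000 nM

Compound 3 reads > 25000 nM, and that is a limit of the assay, not a number. The other two entries are limits as well, so the three compounds cannot be ranked against one another. Two readings cover the whole set: the limit of > 25000 nM in this assay, at which 2 of the 3 values shown sit, and (the limit of > 27000 nM in this assay, at which 1 of the 3 values shown sits).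

Compound 4 `COc1cc2ncnc(-n3nc(-c4ccccn4)nc3N)c2cc1OCCCNC(=O)CN1C[C@@H](C)O[C@@H](C)C1` has not yet been measured. Its difference from compound 3 is (((2,6-dimethylmorpholin-4-yl)methyl)carbonyl)amino in place of 2,6-dimethylmorpholin-4-yl on a saturated chain carbon, three bonds along the chain from an oxygen on an aromatic ring. In words, (((2,6-dimethylmorpholin-4-yl)methyl)carbonyl)amino takes the place of 2,6-dimethylmorpholin-4-yl on a saturated chain carbon, three bonds along the chain from an oxygen on an aromatic ring.

The closest measured change at this end of the chain is a step that the two limits leave unreadable from compound 2 to compound 3. Two more bear on it: a step that the two limits leave unreadable from compound 1 to compound 2, and a step that the two limits leave unreadable from compound 1 to compound 3. None of these has a readable size, yet none of the three groups brought a number out of the limits. No step beyond the usual scatter is therefore expected, and no direction can be named. The expected step is a step that the limit leaves unreadable from compound 3 to compound 4. The estimate for compound 4 is 27000 nM, with an expected range from 12000 nM to 50000 nM, and the assay may well report only a limit again.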

Compound 4, half-maximal effective concentration: > 25000 nM
Compound 4 gave a limit, no number (the forecaster's own chance of this, stated with the estimate: 80%); the middle value lies beyond the limit too.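

Compound 4 reads > 25000 nM, which is a limit of the assay and not a number. Its steps from compound 2 and from compound 3 therefore cannot be read. The compounds shown leave open how far apart the four really lie, and which change on the chain, if any, would give an actual number in this assay.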